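The source may report more compounds than this note shows. Statements on the series, on what has been measured and on what is new or still open speak of the compounds shown alone.

Compound 1 `O=C(O)c1cc(-c2csnn2)ccc1O` was tested in a functional assay on the whole organism for inhibition, with Rattus norvegicus as the target, read by paw edema; on this read-out higher numbers stand for an effect only at larger amounts of compound and lower numbers for an effect already at smaller amounts. In this assay compound 1 gives only a limit, > 200 mg/kg, not a number (the limit of > 200 mg/kg in this assay, at which 1 of the 3 values shown sits). Two related compounds carry other rings on the shared core: compound 2 `O=C(O)c1cc(-n2ccnc2)ccc1O` gives 75 mg/kg and compound 3 `O=C(O)c1cc(-c2ncccn2)ccc1O` gives 100 mg/kg. Within the data shown here, the one measured step from compound 1, an at least 2.6-fold lower number from compound 1 to compound 2 (0.42 log units; beyond the scatter), runs to a lower dose. Compound 4 `O=C(O)c1cc(-c2cncs2)ccc1O` differs from compound 1 by 1,3-thiazol-5-yl in place of 1,2,3-thiadiazol-4-yl on an aromatic carbon. Among the measured compounds shown here, only the step from compound 1 to compound 2 bears on it, so a move of at least modest size in the same direction is expected. The step from compound 1 to compound 4 is estimated at an at least 1.6-fold lower number from compound 1 to compound 4 (0.22 log units; that floor lies within the scatter). Compound 4 is expected to give 120 mg/kg, within 50 mg/kg to 300 mg/kg.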

Compound 4, dose for half-maximal effect: > 200 mg/kg
Compound 4 gave a limit, no number (the forecaster's own chance of this, stated with the estimate: 35%); middle value at least 1.6-fold (0.22 log units) from the limit.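

Compound 4 gives only a limit in this assay, as compound 1 does, so the change from 1,2,3-thiadiazol-4-yl to 1,3-thiazol-5-yl cannot be read: the limit of > 200 mg/kg in this assay, at which 2 of the 4 values shown sit. Removing one ring nitrogen therefore brings no readable gain. Going the other way, 1H-imidazol-1-yl is replaced with an at least 2.6-fold higher number from compound 2 to compound 4 (0.42 log units; beyond the scatter), which shows that this position, para to a hydroxy group, tells these five-membered rings apart. On these data alone, how far compound 1 and compound 4 lie past the limit remains open. So does whether an amine on the 1,3-thiazol-5-yl ring would bring a measurable dose.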